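From methyl to ethyl: what to expect of compound 3

The compounds below may be only part of what the source reports. "The series", "measured", "known", "first", "only" and "open" are said of these compounds alone.

Measured in a functional assay on ECa-109 cells for inhibition, with ECa-109 cell line (Homo sapiens) as the target, read by MTT assay, with a stated time of 48 h; on this read-out higher numbers stand for weaker inhibition and lower numbers for stronger inhibition:
Compound 1 `COc1ccc(-c2coc3cc(OCCCBr)ccc3c2=O)cc1`: 39700 nM
Compound 2 `COc1ccc(-c2coc3cc(OCCCSC(=S)N4CCN(C)CC4)ccc3c2=O)cc1`: 24200 nM

Compound 2 has only compound 1 for comparison: a 1.6-fold lower number from compound 1 to compound 2 (0.21 log units; within the scatter). The two therefore cannot be ranked. Compound 3 `CCN1CCN(C(=S)SCCCOc2ccc3c(=O)c(-c4ccc(OC)cc4)coc3c2)CC1` differs from compound 2 by one small edit: methyl in place of hydrogen on a saturated chain carbon bound to an amine nitrogen in a ring, turning 4-methylpiperazin-1-yl into 4-ethylpiperazin-1-yl. Going by the values given here, no measured step shows this edit itself. Among the compounds with values here, the one available step swapped a much larger group and stayed within the scatter, so no clear shift is expected in this assay, in either direction. The expected change is a 1.0-fold lower number from compound 2 to compound 3 (0.00 log units; within the scatter). For compound 3 the estimated value is 24000 nM, with an expected range of 12000 nM to 48000 nM.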

Compound 3, half-maximal inhibitory concentration: 36900 nM
Estimate against measurement, compound 3: 1.5-fold (0.19 log units) below; the measured number falls inside the stated range.
By their numbers in this assay, from the lowest: compounds 2, 3 and 1 (each within the scatter of the next).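

In this assay, going by these compounds alone, this is the first direct look at the edit from 4-methylpiperazin-1-yl to 4-ethylpiperazin-1-yl: the added methyl gives a 1.5-fold higher number from compound 2 to compound 3 (0.18 log units; within the scatter) and so has no readable effect at this position. Putting the whole ethyl-bearing group in place of bromine gives a 1.1-fold lower number from compound 1 to compound 3 (0.03 log units; within the scatter) and also stays within the scatter. Nothing available here explains these numbers. Still open, from the compounds shown here alone, is whether a longer chain such as propyl, or a benzyl group, in place of the ethyl would move the number beyond the scatter.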